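Adding One Fluoro to the Weakest Compound

The source may hold more compounds than are shown below. What is called first, only, known or untested is meant among the compounds shown, and "the series" means these compounds.

Compound 1 `CC(O)(COc1cccc(C(F)(F)F)c1)C(=O)Nc1ccc(S(F)(F)(F)(F)F)cc1`: 24700 nM
Compound 2 `CC(O)(COc1ccccc1C(F)(F)F)C(=O)Nc1ccc(S(F)(F)(F)(F)F)cc1`: 1200 nM
Compound 3 `CC(O)(COc1ccc(C#N)cc1)C(=O)Nc1ccc(S(F)(F)(F)(F)F)cc1`: 100000 nM

In a functional assay on LNCaP cells (Homo sapiens) for antiproliferative activity, read by propidium iodide staining, with a stated time of 96 h (on this read-out lower numbers stand for stronger inhibition and higher numbers for weaker inhibition), compound 3 gives 100000 nM, the highest of the three numbers and so the weakest inhibition seen here. The gaps to the others, a 4.0-fold higher number from compound 1 to compound 3 (0.61 log units; beyond the scatter) and an 83-fold higher number from compound 2 to compound 3 (1.92 log units; beyond the scatter), are both beyond the scatter.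

Compound 4 `CC(O)(COc1ccc(C#N)c(F)c1)C(=O)Nc1ccc(S(F)(F)(F)(F)F)cc1` differs from compound 3 in one place: fluoro in place of hydrogen on an aromatic carbon. The new fluoro sits ortho to a cyano group, so 4-cyanophenyl becomes 4-cyano-3-fluorophenyl.

Among the compounds with values here, no measured step adds a fluoro, so none gives the size directly. The closest evidence is that changing the group on the oxygen has already shifted the number, as in a 21-fold lower number from compound 1 to compound 2 (1.31 log units; beyond the scatter), which is large. Compound 3 already has the highest number at 100000 nM, so a shift downward seems likelier than one upward, and only a modest one for a single fluoro.

The expected step in this assay is a 2.2-fold lower number from compound 3 to compound 4 (0.35 log units; beyond the scatter). For compound 4 the estimated value is 45000 nM, with an expected range from 10000 nM to 120000 nM.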

Compound 4, half-maximal inhibitory concentration: 100000 nM
The estimate for compound 4 lay 2.2-fold (0.35 log units) below the measured number, within the range that was stated.
By their numbers in this assay, from the lowest: compound 2; then compound 1; then compounds 3 and 4 (each within the scatter of the next).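

In this assay, fluoro placed ortho to a cyano group gives no change at the digits printed from compound 3 to compound 4 (within the scatter), so this single added atom leaves the read-out unmoved at this position. Earlier, swapping the whole group on the oxygen produced large shifts, and the gaps to the trifluoromethyl compounds remain after the fluoro is added, with an 83-fold higher number from compound 2 to compound 4 (1.92 log units; beyond the scatter) and a 4.0-fold higher number from compound 1 to compound 4 (0.61 log units; beyond the scatter). Nothing measured here offers an explanation for the absence of change.

On these data alone, whether a different group at this position, such as a chloro, a methoxy or an amine, would shift the number remains open. Also open, as far as these compounds go, is whether fluoro would make any difference on the 2-(trifluoromethyl)phenyl ring of compound 2, which has the lowest number of the four.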